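This account rests on a few compounds, and the source may have more. Where it says the series, first, only, none or still open, it means among the compounds named here.

Of the compounds shown here, three sharing one core have been tested in a functional assay on BXPC-3 cells (Homo sapiens) for antiproliferative activity, read by MTT assay, with a stated time of 24 h; a lower number here means a stronger inhibitor, a higher number a weaker inhibitor. Compound 1 `CCn1c(C(=O)N[C@H](C)CO)ccc1C(CC)(CC)c1ccc(OCS(=O)(=O)c2ccccc2)c(C)c1` gives 10000 nM. Compound 2 `CCn1c(C(=O)N[C@@H](CO)CCCO)ccc1C(CC)(CC)c1ccc(OCS(=O)(=O)c2ccccc2)c(C)c1` gives 16400 nM, and compound 3 `CCn1c(C(=O)N[C@@H](C)C(=O)O)ccc1C(CC)(CC)c1ccc(OCS(=O)(=O)c2ccccc2)c(C)c1` gives 20800 nM. On these numbers compound 1 stands at the low end, but only its gap to compound 3 counts as a real difference: the step of a 1.6-fold higher number from compound 1 to compound 2 (0.21 log units; within the scatter) stays inside the scatter, while the step of a 2.1-fold higher number from compound 1 to compound 3 (0.32 log units; beyond the scatter) is modest but beyond it, and the step of a 1.3-fold higher number from compound 2 to compound 3 (0.10 log units; within the scatter) is again inside it.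

Compound 4 `CCn1c(C(=O)N[C@@H](CCC(=O)O)C(=O)O)ccc1C(CC)(CC)c1ccc(OCS(=O)(=O)c2ccccc2)c(C)c1` is not yet measured. Against compound 1 it carries 1,3-dicarboxypropyl in place of 1-(hydroxymethyl)ethyl on an amide-type nitrogen. Among the measured compounds shown here, two measured steps bear on this. Putting a 1-carboxyethyl group on the amide-type nitrogen in place of the 1-(hydroxymethyl)ethyl group, from compound 1 to compound 3, gave a modest rise in the number; extending the chain, from compound 1 to compound 2, changed nothing beyond the scatter. Compound 4 carries both kinds of change at once, so a rise of similar size is expected in this assay, and compound 4 is estimated to show the step of a 2.5-fold higher number from compound 1 to compound 4 (0.40 log units; beyond the scatter). Compound 4 is therefore expected to give about 25000 nM, most likely between 10000 nM and 60000 nM.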

Compound 4, half-maximal inhibitory concentration: > 50000 nM
Compound 4: a limit, no number; the forecaster's own chance of this, stated with the estimate: 25%; middle value at least 2.0-fold (0.30 log units) away from the limit.
By their numbers in this assay, from the lowest: compounds 1, 2 and 3 (each within the scatter of the next, the first and the last beyond it). At a limit, above all of these: compound 4.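

In this assay, compound 4 is recorded as a limit and not as a number: the limit of > 50000 nM in this assay, at which 1 of the 4 values shown sits.

Even so, this position on the amide-type nitrogen proves more sensitive than the earlier compounds showed, for among them only one step, a 2.1-fold higher number from compound 1 to compound 3 (0.32 log units; beyond the scatter), left the scatter, and that only modestly. The 1,3-dicarboxypropyl group gives clearer separation, with an at least 5.0-fold higher number from compound 1 to compound 4 (0.69 log units; beyond the scatter) and an at least 3.0-fold higher number from compound 2 to compound 4 (0.48 log units; beyond the scatter). The most telling comparison is an at least 2.4-fold higher number from compound 3 to compound 4 (0.38 log units; beyond the scatter), where carboxymethyl replaces a hydrogen on a saturated chain carbon, showing that this one addition to a group already bearing a carboxylic acid moves the result beyond the scatter, whereas the 2-hydroxyethyl addition from compound 1 to compound 2 did not.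

From the compounds shown here alone, the true size of these steps stays unknown, since the result for compound 4 gives only a limit. Also open, going by these compounds, is whether the rise depends on the carboxylic acid at the end of the added chain, a question that a chain of the same length ending in an amine, a methyl ester or a plain methyl group would address.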